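Ring Size on the Ketone: From Cyclopropyl to Cyclopentyl

This account rests on a few compounds, and the source may have more. Where it says the series, first, only, none or still open, it means among the compounds named here.

The study compares two ketones that share one core and differ only in the group on the carbonyl carbon. Compound 1 `COC(=O)CCC(=O)c1ncc(-c2ccccn2)o1` carries a 2-(methoxycarbonyl)ethyl group there. In an assay for inhibition of Fatty-acid amide hydrolase 1 (Rattus norvegicus) (a lower number here means a stronger inhibitor, a higher number a weaker inhibitor), compound 1 reaches only the assay limit of > 100000 nM. Compound 2 `O=C(c1ncc(-c2ccccn2)o1)C1CC1` carries a cyclopropyl group on the same carbonyl carbon. In this assay compound 2 likewise reaches only a limit, > 50000 nM. The step that the two limits leave unreadable from compound 1 to compound 2 can therefore not be read, since both ends are limits, as noted for the limit of > 100000 nM in this assay, at which 1 of the 2 values shown sits, and (the limit of > 50000 nM in this assay, at which 1 of the 2 values shown sits). Compound 2 thus stands at a limit, with no measured number to anchor it.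

Compound 3 `O=C(c1ncc(-c2ccccn2)o1)C1CCCC1` is the next member. It differs from compound 2 by cyclopentyl in place of cyclopropyl on a carbonyl carbon. Going by the values given here, no measured step speaks to a change of this kind, and the one step available is unreadable, so no direction beyond the scatter can be argued. The step from compound 2 to compound 3 is expected to be a number no higher from compound 2 to compound 3 (the limit leaves the size open). Compound 3 is accordingly estimated at 50000 nM, within a range from 5000 nM to 300000 nM.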

Compound 3, inhibition constant: 2500 nM
The estimate for compound 3 lay 20-fold (1.30 log units) above the measured number; the measured number lies below the stated range.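

In this assay, cyclopentyl in place of cyclopropyl on the carbonyl carbon gives an at least 20-fold lower number from compound 2 to compound 3 (1.30 log units; beyond the scatter), and cyclopentyl in place of 2-(methoxycarbonyl)ethyl on that carbon gives an at least 40-fold lower number from compound 1 to compound 3 (1.60 log units; beyond the scatter). Going by these compounds alone, the earlier pair could not show that this carbonyl carbon responds to its group at all, since the one step it offered cannot be read, whereas both new steps lie beyond the scatter and rest on a measured number at one end. Compound 2 stands at a limit, so the step from it has a lower bound and no fixed size: the limit of > 50000 nM in this assay, at which 1 of the 3 values shown sits.

Compound 1 also stands at a limit, which leaves the full size of its step to the cyclopentyl ketone equally open: the limit of > 100000 nM in this assay, at which 1 of the 3 values shown sits. The compounds shown also leave open whether cyclobutyl or cyclohexyl on the same carbonyl carbon would continue or break the change seen with cyclopentyl, and whether a longer unbranched alkyl chain or an amine there would give a measured number at all, so three compounds with a single measured number support no trend in ring size.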